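The source may report more compounds than this note shows. Statements on the series, on what has been measured and on what is new or still open speak of the compounds shown alone.

Of the compounds shown here, two built on one shared core have so far been measured in a functional assay on the whole organism for inhibition, with Rattus norvegicus as the target, at a dose of 1 mg/kg by the oral route; a higher number here means more inhibition at the dose given (going by the name of the read-out), a lower number less inhibition. Compound 1 `N#Cc1c(N)cccc1NC(=O)C(=O)O` carries only hydrogen on its ring nitrogen, and in this assay compound 1 gives 21.2%. Compound 2 `CNc1cccc(NC(=O)C(=O)O)c1C#N` differs from it by methyl in place of hydrogen on that nitrogen, and in this assay compound 2 gives 96%. For the measured compounds named here, that single measured step, a number 74.8 percentage points higher from compound 1 to compound 2 (beyond the scatter), places compound 2 highest of the two numbers, with compound 1 as its only neighbour far below it.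

Compound 3 `CCN(C)c1cccc(NC(=O)C(=O)O)c1C#N` has not yet been measured. It differs from compound 2 by ethyl in place of hydrogen on a nitrogen on an aromatic ring. Going by the values given here, the one measured step bears on this only loosely: it shows that a first small carbon group on this nitrogen went with a sharp rise in inhibition, but it says nothing about a second, longer group on a nitrogen that already carries methyl. The read-out of compound 2 also sits near the top of what a percentage can show, leaving little room to rise. The expected step is therefore a number 14 percentage points lower from compound 2 to compound 3 (beyond the scatter), modest and uncertain in direction. Compound 3 is estimated at 82%, within a range from 45% to 100%.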

Compound 3, a percentage reported as inhibition, in the whole organism at one dose (the size of the read-out at that dose, not a potency): 56.3%
Compound 3: the middle estimate sits 25.7 percentage points above what was measured, and the stated range covers the measured number.
By their numbers in this assay, from the lowest: compound 1; then compound 3; then compound 2.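

In this assay, the result shows that more carbon on this nitrogen does not simply mean more inhibition: the change from methylamino to ethyl(methyl)amino gives a number 39.7 percentage points lower from compound 2 to compound 3 (beyond the scatter), whereas the first methyl gave a number 74.8 percentage points higher from compound 1 to compound 2 (beyond the scatter). The nitrogen therefore does not follow a steady trend across these three compounds, and among them the methylamino group of compound 2 gives the highest number, with both neighbours beyond the scatter from it. The larger group still keeps much of the gain over the plain amino group, with ethyl(methyl)amino in place of amino giving a number 35.1 percentage points higher from compound 1 to compound 3 (beyond the scatter), yet nothing at hand explains why the number rises and then falls along this series.

Compound 3 differs from compound 2 in two linked ways, since it gains an ethyl group and also loses the last hydrogen on this nitrogen, so the fall cannot yet be assigned to either one. A dimethylamino group would keep that nitrogen free of hydrogen without any ethyl, an ethylamino group would keep the hydrogen alongside ethyl, and a longer chain such as propyl would show whether the number keeps falling as the chain grows.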